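Removing the aryl urea: what a plain benzamide might do

A few compounds are considered here, and "the series" means these few. Any claim that something is new, unique, unknown or untested is made for them only; others in the source may bear on it.

Of the compounds shown here, three sharing one core have been tested in a functional assay on NCI-H322M cells (Homo sapiens) for inhibition, read by sulforhodamine B assay, with a stated time of 48 h; a lower number here means a stronger inhibitor of growth, a higher number a weaker inhibitor of growth. Compound 1 `COc1cc(-c2nn(-c3cccc(NC(=O)Nc4ccc(Cl)c(Cl)c4)c3)cc2-c2ccncc2)ccc1Cl` reaches only the limit > 50000 nM in this assay. Compound 2 `COc1cc(-c2nn(-c3cccc(NC(=O)Nc4cccc(C(F)(F)F)c4)c3)cc2-c2ccncc2)ccc1Cl` gives 4730 nM, and compound 3 `COc1cc(-c2nn(-c3cccc(NC(=O)Nc4ccc(Cl)c(C(F)(F)F)c4)c3)cc2-c2ccncc2)ccc1Cl` gives 13900 nM. Compound 3 therefore stands highest of the two numbers, with the step of a 2.9-fold higher number from compound 2 to compound 3 (0.47 log units; beyond the scatter) separating it from compound 2, while the steps of an at least 10-fold lower number from compound 1 to compound 2 (1.02 log units; beyond the scatter) and an at least 3.5-fold lower number from compound 1 to compound 3 (0.55 log units; beyond the scatter) show how much the substituents on the outer ring matter. Compound 4 `COc1cc(-c2nn(-c3cccc(NC(=O)c4ccccc4)c3)cc2-c2ccncc2)ccc1Cl` carries a different change: phenyl in place of (4-chloro-3-(trifluoromethyl)phenyl)amino on a carbonyl carbon. Going by the values given here, no measured step swaps this whole group, so the three steps guide only loosely; since each change on the outer ring moved the number clearly, this larger change is expected to weaken inhibition, with compound 4 estimated at 30000 nM (range 8000 nM to 50000 nM), a step of a 2.2-fold higher number from compound 3 to compound 4 (0.33 log units; beyond the scatter).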

Compound 4, concentration for total growth inhibition: > 100000 nM
Compound 4: only a limit was reported; the forecaster's own chance of this, stated with the estimate: 35%; middle value at least 3.3-fold (0.52 log units) away from the limit.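

Compound 4 gives only a limit: the limit of > 100000 nM in this assay, at which 1 of the 4 values shown sits. The change to a plain benzamide costs growth inhibition, with an at least 7.1-fold higher number from compound 3 to compound 4 (0.85 log units; beyond the scatter) and an at least 21-fold higher number from compound 2 to compound 4 (1.32 log units; beyond the scatter) so in these two pairs the aryl amino part on the carbonyl carbon is needed for a measured number. Compound 1 keeps such a part yet also stops at a limit, so that part alone is not enough, and its step to compound 4 cannot be read.

Still open, on these data alone, is whether the urea nitrogen or the outer ring's substituents matter more. A cyclohexylamino group on the carbonyl carbon, or a 3-(trifluoromethyl)phenyl group there, would help separate the two.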